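The source may hold more compounds than are shown below. What is called first, only, known or untested is meant among the compounds shown, and "the series" means these compounds.

Two compounds in this series carry a measurement. Compound 1 `COc1cc2c(Oc3ccc(NC(=O)c4nn(-c5ccccc5)cc(C)c4=O)cc3)ccnc2cc1OCCCCCCC(=O)NO` stands at the lower of the two numbers in a functional assay on MCF7 cells (Homo sapiens) for inhibition, read by MTT assay, with a stated time of 72 h (a higher number here means a weaker inhibitor, a lower number a stronger inhibitor), giving 1610 nM. Compound 2 `COc1cc2c(Oc3ccc(NC(=O)c4nn(-c5ccccc5F)cc(C)c4=O)cc3F)ccnc2cc1OCCCCCC(=O)NO` gives 2320 nM in this assay; the two numbers lie within the usual scatter of each other, so neither compound is to be called the stronger inhibitor. Going by the values given here, compound 2 differs from compound 1 in more than one place and no step between the two is counted, so the pair shows only that the two values sit close together.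

Compound 3 `COc1cc2c(Oc3ccc(NC(=O)c4nn(-c5cccc(C)c5)cc(C)c4=O)cc3)ccnc2cc1OCCCCCCC(=O)NO` has not yet been measured. It differs from compound 1 in one place: methyl in place of hydrogen on an aromatic carbon. Cut one bond further out, the change reads phenyl to 3-methylphenyl. Among the compounds with values here, no measured pair differs by this change alone, so the measured compounds give no step to lean on. A small step is expected, none beyond the scatter in either direction. The estimated step reads a 1.1-fold lower number from compound 1 to compound 3 (0.03 log units; within the scatter). For compound 3 the value expected in this assay is 1500 nM, with a range from 700 nM to 3500 nM.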

Compound 3, half-maximal inhibitory concentration: 1680 nM
Compound 3: middle estimate off by 1.1-fold (0.05 log units), on the low side, and the stated range covers the measured number.
By their numbers in this assay, from the lowest: compounds 1, 3 and 2 (each within the scatter of the next).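

In this assay, going by these compounds alone, the change from phenyl to 3-methylphenyl gives the first step that can be read at a single place, and a 1.0-fold higher number from compound 1 to compound 3 (0.02 log units; within the scatter) is what that step amounts to. A methyl on this aromatic carbon, meta to a large group, therefore leaves the number within the scatter of compound 1, something the pair of compound 1 and compound 2 could not show, as those two differ in more than one place. No measurement at hand bears on why the number holds at this position, and this single step speaks for one group on one carbon only.

Still open, from the compounds shown here alone, is whether a larger or differently built group on the same carbon, such as trifluoromethyl, methoxy, an amine or a carboxylic acid, would give a step beyond the scatter, and whether a methyl on any other carbon of the phenyl would behave as this one does. Also open, going by these compounds, is what a shorter or longer chain does on its own, with everything else in compound 1 held fixed.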